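The compounds below may be only part of what the source reports. "The series", "measured", "known", "first", "only" and "open" are said of these compounds alone.

The measured compounds in a functional assay on HPAC cells (Homo sapiens) for inhibition, read by MTT assay, with a stated time of 72 h (a lower number here means a stronger inhibitor of growth, a higher number a weaker inhibitor of growth), are:

compound 1, `O=S(=O)(NCCCNCc1ccc(Cl)cc1)c1cc(C(F)(F)F)cc(C(F)(F)F)c1`, which gives 2800 nM
compound 2, `CC(C)(C)c1ccc(CNCCCNS(=O)(=O)c2cc(C(F)(F)F)cc(C(F)(F)F)c2)cc1`, which gives 2300 nM
compound 3, `O=S(=O)(NCCCNCc1cccc(Cl)c1)c1cc(C(F)(F)F)cc(C(F)(F)F)c1`, which gives 2700 nM

Compound 3 stands second highest of the three numbers; its nearest neighbour is compound 1, with a 1.0-fold lower number from compound 1 to compound 3 (0.02 log units; within the scatter) separating them, and its furthest is compound 2, with a 1.2-fold higher number from compound 2 to compound 3 (0.07 log units; within the scatter) between them. All three numbers sit within the usual scatter of one another.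

Compound 4 is `O=S(=O)(NCCCNCc1ccc(Cl)c(C(F)(F)F)c1)c1cc(C(F)(F)F)cc(C(F)(F)F)c1`. The change from compound 3 is 4-chloro-3-(trifluoromethyl)phenyl in place of 3-chlorophenyl on a saturated chain carbon bound to an amine nitrogen. Among the compounds with values here, the steps that bear on it are the ones that vary this same aryl group: a 1.0-fold lower number from compound 1 to compound 3 (0.02 log units; within the scatter), a 1.2-fold lower number from compound 1 to compound 2 (0.09 log units; within the scatter) and a 1.2-fold higher number from compound 2 to compound 3 (0.07 log units; within the scatter). Each is within the scatter, so changing the substituent pattern on this ring has so far left this assay unchanged. Within the data shown here, no measured step adds a trifluoromethyl to this ring, so nothing beyond that is known.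

Compound 4 is therefore expected to show no step beyond the scatter, a 1.1-fold lower number from compound 3 to compound 4 (0.05 log units; within the scatter). The estimate for compound 4 is 2400 nM, with a range from 1200 nM to 5000 nM.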

Compound 4, concentration for 50% growth inhibition: 3000 nM
The estimate for compound 4 lay 1.3-fold (0.10 log units) below the measured number; the range from low to high includes it.
By their numbers in this assay, from the lowest: compounds 2, 3, 1 and 4 (each within the scatter of the next).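

In this assay, trifluoromethyl in place of hydrogen on an aromatic carbon gives a 1.1-fold higher number from compound 1 to compound 4 (0.03 log units; within the scatter), so this is the first step shown to add a group to this ring rather than exchange or move one, and it stays within the scatter. The exchanges that bring in 4-chloro-3-(trifluoromethyl)phenyl read the same way, with a 1.1-fold higher number from compound 3 to compound 4 (0.05 log units; within the scatter) and a 1.3-fold higher number from compound 2 to compound 4 (0.12 log units; within the scatter), so all four aryl groups on this saturated chain carbon bound to an amine nitrogen give numbers within the scatter of one another. No supporting data offer an account of this flat result.

Going by these compounds, all four compounds keep an aromatic ring of carbon only at this place, so it remains open whether a carboxylic acid on that ring or a piperidine in its stead would step beyond the scatter. They also share the rest of the core of compound 1, which leaves open what a longer chain would do.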